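Side-chain shortening from compound 1 to compound 3

The compounds below may be only part of what the source reports. "The series", "measured", "known", "first", "only" and "open" are said of these compounds alone.

Compound 1 `NC(=O)CC[C@H](NC(=O)CN(c1ncnc2c1ncn2C1CCCCO1)C1CC1)C(=O)OCc1ccccc1` gives 47% in a functional assay on the whole organism (Tail, strain ICR) with Mus musculus as the target, in the tail flick test, with a stated time of 30 min, at a dose of 25 umol/kg by the oral route (on this read-out higher numbers stand for a stronger effect at the one dose given and lower numbers for a weaker effect), the upper of the two numbers in hand. Compound 2 `O=C(CN(c1nc(Cl)nc2[nH]cnc12)C1CC1)N[C@@H](CO)C(=O)O` gives 38.7% in this assay, and the gap to compound 1 lies within the scatter, so the two are not separated. Compound 3 `NC(=O)C[C@H](NC(=O)CN(c1ncnc2c1ncn2C1CCCCO1)C1CC1)C(=O)OCc1ccccc1` is not yet measured. It differs from compound 1 by carbamoyl in place of carbamoylmethyl on a saturated chain carbon, two bonds along the chain from an amide-type nitrogen and a carbonyl carbon. For the measured compounds named here, no step between measured compounds covers this change, so the expected step of a number 5 percentage points lower from compound 1 to compound 3 (within the scatter) is taken as small, with no direction beyond the scatter. Compound 3 is expected to give about 42%, in the range 20% to 65%.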

Compound 3, a percentage reported as activity, at one dose (the size of the read-out at that dose, not a potency): 34.5%
For compound 3 the middle estimate is 7.5 percentage points above the measured one; measured number inside the range.
By their numbers in this assay, from the lowest: compounds 3, 2 and 1 (each within the scatter of the next, the first and the last beyond it).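

In this assay, for the compounds shown here, this position on the saturated chain carbon responds to chain length: going from 2-carbamoylethyl to carbamoylmethyl, with the carbamoyl group kept, gives the only step in hand (a number 12.5 percentage points lower from compound 1 to compound 3 (beyond the scatter)), and it is modest. Compounds 1 and 2 differ in more than one place and could not show this. Nothing available accounts for the step.

Going by these compounds, it remains open whether a longer chain would hold or raise the read-out. Also open, on these data alone, is how a carboxylic acid or an amine in place of carbamoyl would compare.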